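Methoxy Removal on a Bis-indole Acrylonitrile Scaffold

The compounds below may be only part of what the source reports. "The series", "measured", "known", "first", "only" and "open" are said of these compounds alone.

Compound 2 `COc1ccc2c(C(=O)/C(C#N)=C/c3c[nH]c4cc(F)ccc34)c[nH]c2c1` carries a methoxy group on one of its two indole cores. In a functional assay on PC-3 cells (Homo sapiens) for cytotoxicity, read by WST assay, with a stated time of 48 h (a lower number here means a stronger inhibitor, a higher number a weaker inhibitor), compound 2 gives 22500 nM. Compound 1 `N#C/C(=C\c1c[nH]c2cc(F)ccc12)C(=O)c1c[nH]c2ccccc12` lacks that group. In this assay compound 1 gives only a limit, > 50000 nM. The change here is hydrogen in place of methoxy on an aromatic carbon, and it produced an at least 2.2-fold higher number from compound 2 to compound 1 (0.34 log units; beyond the scatter). Compound 3 `COc1ccc2c(C(=O)/C(C#N)=C/c3cn(Cc4ccc(Cl)cc4)c4ccccc34)c[nH]c2c1` keeps the methoxy but differs from compound 2 elsewhere; the difference between the two cores is not broken down here. In this assay compound 3 also gives a limit, > 50000 nM. Compound 4 `N#C/C(=C\c1cn(Cc2ccc(Cl)cc2)c2ccccc12)C(=O)c1c[nH]c2ccccc12` is compound 3 stripped of the methoxy, the change being (hydrogen in place of methoxy on an aromatic carbon), the same change as the one already measured. Two of the three measured values sit at the limit of > 50000 nM in this assay, at which 2 of the 3 values shown sit. The measured step points toward a higher number once the methoxy is gone, and the starting point is already a limit, so the expected step is a step that the limit leaves unreadable from compound 3 to compound 4, resting on an at least 2.2-fold higher number from compound 2 to compound 1 (0.34 log units; beyond the scatter). Compound 4 is therefore expected to give 90000 nM, within a range from 40000 nM to 250000 nM, and most likely to be reported only as a limit.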

Compound 4, half-maximal inhibitory concentration: > 50000 nM
Compound 4: only a limit was reported; the forecaster's own chance of this, stated with the estimate: 90%; the middle value lies beyond the limit too.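

In this assay, compound 3 and compound 4 both give only a limit, so no step can be read between them: the limit of > 50000 nM in this assay, at which 3 of the 4 values shown sit.

The compounds shown leave open whether going from 6-methoxy-1H-indol-3-yl to 1H-indol-3-yl shifts the number for compound 4 in the same direction as it does for compound 1.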